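Indole carbonyl in place of a benzyl group at sigma-1

The source may hold more compounds than are shown below. What is called first, only, known or untested is meant among the compounds shown, and "the series" means these compounds.

Of the compounds shown here, three of a shared core have been measured in an assay on membranes from Cortex for displacement of a labelled ligand from Sigma non-opioid intracellular receptor 1 (Cavia porcellus), read by scintillation counting, with a stated time of 120 min; a higher number here means a weaker inhibitor, a lower number a stronger inhibitor. Compound 1 `Fc1ccc(C(SCCNC2CCN(Cc3ccc(Cl)cc3)CC2)c2ccc(F)cc2)cc1` gives 45.5 nM, compound 2 `Fc1ccc(C(SCCNC2CCN(Cc3ccc(C(F)(F)F)cc3)CC2)c2ccc(F)cc2)cc1` gives 186 nM, and compound 3 `[O-][S+](CCNC1CCN(Cc2ccc(F)cc2)CC1)C(c1ccc(F)cc1)c1ccc(F)cc1` gives 26.5 nM. Among the measured compounds shown here, the single one-place step among them, a 4.1-fold higher number from compound 1 to compound 2 (0.61 log units; beyond the scatter), is a modest one. Compound 2 therefore stands at the highest number of the three, with compound 1 nearest and compound 3 furthest; compound 3 differs from compound 2 in two places, so its lower number can only be noted, not traced to one change.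

Compound 4 `O=C(c1cc2ccccc2[nH]1)N1CCC(NCCSC(c2ccc(F)cc2)c2ccc(F)cc2)CC1` is not yet measured. It differs from compound 2 in that ((1H-indol-2-yl)carbonyl in place of 4-(trifluoromethyl)benzyl on an amine nitrogen in a ring). For the measured compounds named here, no measured step touches this position in this way: the only step known at the same nitrogen, a 4.1-fold higher number from compound 1 to compound 2 (0.61 log units; beyond the scatter), swaps one substituent on the benzyl ring and keeps the benzyl itself. That step gives no guide for removing the whole benzyl and putting an amide in its place, so the direction in this assay is open and any expectation must be wide. Compound 4 is expected to fall near 250 nM, within 50 nM to 1200 nM, which means an expected step of a 1.3-fold higher number from compound 2 to compound 4 (0.13 log units; within the scatter).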

Compound 4, inhibition constant: 1130 nM
Estimate against measurement, compound 4: 4.5-fold (0.66 log units) below; low and high end bracket the measured number.
By their numbers in this assay, from the lowest: compounds 3 and 1 (each within the scatter of the next); then compound 2; then compound 4.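

In this assay, among the compounds shown here, the earlier compounds showed only what a change of substituent on a retained benzyl ring does, whereas compound 4 shows what happens when the whole benzyl group on this ring nitrogen is replaced by (1H-indol-2-yl)carbonyl. The replacement gives a 6.1-fold higher number from compound 2 to compound 4 (0.78 log units; beyond the scatter) and a 25-fold higher number from compound 1 to compound 4 (1.40 log units; beyond the scatter), so both steps run towards a weaker inhibitor and lie beyond the scatter, the first modest and the second large. The change swaps a benzyl group for an amide carbonyl and an indole, and no measurement here says which part of it accounts for the higher number.

The compounds shown leave open whether the loss follows the carbonyl or the indole, which a benzoyl group on the same nitrogen or a (1H-indol-2-yl)methyl group there could separate. They also leave open whether the (1H-indol-2-yl)carbonyl group would give the same result with a sulfoxide in place of the thioether sulfur, the form carried by compound 3.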